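The compounds below may be only part of what the source reports. "The series", "measured", "known", "first", "only" and "open" are said of these compounds alone.

Measured compounds in a functional assay on CWR22R cells (Homo sapiens) for inhibition, with a stated time of 120 h, tested at 10 uM; a higher number here means more inhibition at the concentration tested (going by the name of the read-out), a lower number less inhibition:
Compound 1 `Cc1n[nH]c2ccc(-c3nc4cnc(N5CCN(C)CC5)cn4c3Nc3ccccc3F)cc12` gives 0%.
Compound 2 `Cc1n[nH]c2ccc(-c3nc4cnc(N5CCN(C)CC5)cn4c3Nc3cccc(F)c3)cc12` gives 5.41%.
Compound 3 `Cc1n[nH]c2ccc(-c3nc4cnc(N5CCN(C)CC5)cn4c3Nc3cccc(Cl)c3)cc12` gives "not determined" (no result reported).

Compound 2 holds the higher of the two numbers in this assay, though the step of a number 5.4 percentage points higher from compound 1 to compound 2 (within the scatter) lies within the scatter, so the two are not told apart. Compound 4 `Cc1n[nH]c2ccc(-c3nc4cnc(N5CCN(C)CC5)cn4c3Nc3ccc(Br)cc3)cc12` differs from compound 2 by 4-bromophenyl in place of 3-fluorophenyl on a nitrogen on an aromatic ring. Within the data shown here, no measured step covers this exchange; the only step known, a number 5.4 percentage points higher from compound 1 to compound 2 (within the scatter), moves a fluorine around the ring and stays within the scatter, and compound 3 gives no number. Since compound 2 shows 5.41% and compound 1 0%, compound 4 is expected to stay in the same low region, with the estimated step of a number 0.6 percentage points higher from compound 2 to compound 4 (within the scatter) not going beyond the scatter. Compound 4 is therefore estimated at 6%, between 0% and 22%.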

Compound 4, a percentage reported as inhibition, at one concentration (the size of the read-out at that concentration, not a potency): 11.7%
Beside the measured number, compound 4's estimate is 5.7 percentage points below it; the range from low to high includes it.
By their numbers in this assay, from the lowest: compounds 1, 2 and 4 (each within the scatter of the next, the first and the last beyond it).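

In this assay, 4-bromophenyl in place of 3-fluorophenyl on the aromatic-ring nitrogen gives a number 6.3 percentage points higher from compound 2 to compound 4 (within the scatter), so these two compounds are not told apart. Among these compounds, the same group in place of 2-fluorophenyl gives a number 11.7 percentage points higher from compound 1 to compound 4 (beyond the scatter), the first step at this position to pass the scatter, though only modestly. Nothing measured here explains this step.

From the compounds shown here alone, whether it follows the bromine or the ring position stays open, and a 4-fluorophenyl or 3-bromophenyl group would separate the two. Going by these compounds, how an amine or a carboxylic acid on this phenyl ring would read also remains unknown.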